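Moving a hydroxyl around a phenyl ring on a purine scaffold

A few compounds are considered here, and "the series" means these few. Any claim that something is new, unique, unknown or untested is made for them only; others in the source may bear on it.

Of the compounds shown here, three share one core and have been tested in a functional assay on K562 cells (Homo sapiens) for inhibition, read by fluorescence, with a stated time of 72 h; on this read-out higher numbers stand for weaker inhibition of growth and lower numbers for stronger inhibition of growth. Compound 1 `CC(C)CCn1cnc2c(Nc3cccc(O)c3)nc(N[C@H]3CC[C@H](N)CC3)nc21` gives 7600 nM in this assay, the highest of the three numbers. Compound 2 `CCCCCCn1cnc2c(Nc3cccc(Cl)c3)nc(N[C@H]3CC[C@H](N)CC3)nc21` gives 2300 nM in this assay, and compound 3 `CCCCCCn1cnc2c(Nc3cc(OC)cc(OC)c3)nc(N[C@H]3CC[C@H](N)CC3)nc21` gives 1900 nM in this assay; both steps down from compound 1 lie beyond the scatter. Among the measured compounds shown here, the one measured step between compounds differing in a single place, a 1.2-fold lower number from compound 2 to compound 3 (0.08 log units; within the scatter), concerns the aryl group on a nitrogen on an aromatic ring and falls within the scatter.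

Compound 4 `CC(C)CCn1cnc2c(Nc3ccc(O)cc3)nc(N[C@H]3CC[C@H](N)CC3)nc21` has the same atoms as compound 1, joined differently: 4-hydroxyphenyl in place of 3-hydroxyphenyl on a nitrogen on an aromatic ring. For the measured compounds named here, no measured pair here tests this kind of change, and the one pair that alters the same aryl group shows a step within the scatter. In this assay, compound 4 is therefore expected to show a 1.2-fold lower number from compound 1 to compound 4 (0.07 log units; within the scatter), a step not beyond the scatter, and its growth-inhibition concentration is estimated at 6500 nM, with a range from 2000 nM to 20000 nM.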

Compound 4, concentration for 50% growth inhibition: 4600 nM
For compound 4 the middle estimate is 1.4-fold (0.15 log units) above the measured one; the measured number falls inside the stated range.
By their numbers in this assay, from the lowest: compounds 3, 2, 4 and 1 (each within the scatter of the next, the first and the last beyond it).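

Moving the hydroxyl on the aryl group, with the rest of the molecule unchanged, gives in this assay a 1.7-fold lower number from compound 1 to compound 4 (0.22 log units; within the scatter) so this pair does not separate the two placements. Among the compounds shown here, on a nitrogen on an aromatic ring, 3-hydroxyphenyl and 4-hydroxyphenyl therefore read alike, something the earlier compounds could not show: their only single-place step put 3,5-dimethoxyphenyl in place of 3-chlorophenyl and involved no hydroxyl. No measurement offered here explains this closeness.

On these data alone, whether the hydroxyl itself matters remains open, and an amine or a carboxylic acid in its place on the same ring would begin to test that. As far as these compounds go, the effect of the chain on the core also remains open, since compounds 2 and 3 differ from compound 1 in both the chain and the aryl group.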